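A few compounds are considered here, and "the series" means these few. Any claim that something is new, unique, unknown or untested is made for them only; others in the source may bear on it.

Going by the values given here, in a functional assay on MCF7 cells (Homo sapiens) for antiproliferative activity, read by MTT assay (a higher number here means a weaker inhibitor, a lower number a stronger inhibitor), compound 1 `COc1cc2c(Oc3ccc(NC(=O)N/N=C/c4ccccc4)cc3)ccnc2cc1OCCCCCCC(=O)NO` gives 610 nM and compound 2 `COc1cc2c(Oc3ccc(NC(=O)N/N=C/c4ccccc4F)cc3)ccnc2cc1OCCCCCCC(=O)NO` gives 1610 nM, the higher of the two numbers so far. Among the compounds with values here, the only measured step, a 2.6-fold higher number from compound 1 to compound 2 (0.42 log units; beyond the scatter), is modest and comes from fluoro replacing hydrogen on an aromatic carbon. Compound 3 `COc1cc2c(Oc3ccc(NC(=O)NNC(=O)c4ccccc4)cc3)ccnc2cc1OCCCCCCC(=O)NO` differs from compound 2 on an amide-type nitrogen: a group of 9 heavy atoms (7 carbon, 1 nitrogen, 1 oxygen; one six-membered aromatic ring of carbon only) in place of a group of 9 heavy atoms (7 carbon, 1 nitrogen, 1 fluorine; one six-membered aromatic ring of carbon only), on an amide-type nitrogen. Benzamido has not been measured in any compound, so that step bears on this change only in part. Like compound 1 at 610 nM, compound 3 carries no fluorine, and this points to a lower number than that of compound 2 in this assay. The expected change is small, within the scatter: a 1.8-fold lower number from compound 2 to compound 3 (0.25 log units; within the scatter). Compound 3 is estimated at 900 nM, with an expected range of 300 nM to 2800 nM.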

Compound 3, half-maximal inhibitory concentration: 2450 nM
Beside the measured number, compound 3's estimate is 2.7-fold (0.43 log units) below it, and the stated range covers the measured number.
By their numbers in this assay, from the lowest: compound 1; then compounds 2 and 3 (each within the scatter of the next).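

In this assay the benzamido group on this amide-type nitrogen gives a 4.0-fold higher number from compound 1 to compound 3 (0.60 log units; beyond the scatter) and so, like the fluoro change, moves the number up from that of compound 1. Against the fluorinated group it gives a 1.5-fold higher number from compound 2 to compound 3 (0.18 log units; within the scatter) and this assay does not separate them, even though benzamido carries a hydrogen-bond donor where the group it replaces has none. Nothing available explains this result.

The compounds shown leave open whether a fluoro on the benzamido ring would change the number of compound 3 as it changed that of compound 1. They also leave open how a smaller acetamido group or a sulfonamide linkage at this nitrogen would compare, and whether chloro or methoxy on the aromatic ring would follow fluoro.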